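The compounds below may be only part of what the source reports. "The series", "measured", "known", "first", "only" and "open" are said of these compounds alone.

Three dihydropyridine diesters were measured in an assay on isolated protein (strain albino) for antagonist activity at Voltage-dependent L-type calcium channel subunit alpha-1C (Cavia porcellus); on this read-out lower numbers stand for stronger inhibition and higher numbers for weaker inhibition. Compound 1 `CSc1ncc(C2C(C(=O)OCC(C)C)=C(C)NC(C)=C2C(=O)OCC(C)C)n1Nc1ccccc1` gives 6.71 nM. Compound 2 `COC(=O)C1=C(C)NC(C)=C(C(=O)OC)C1c1cnc(SC)n1Nc1ccccc1` gives 3.54 nM. Compound 3 `CSc1ncc(C2C(C(=O)OCc3ccccc3)=C(C)NC(C)=C2C(=O)OCc2ccccc2)n1Nc1ccccc1` gives 1.49 nM, the lowest of the three numbers; its gap to compound 2 and its larger gap to compound 1 both lie beyond the usual scatter of this assay, so compound 3 is the most potent of the measured set.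

Compound 4 `CCOC(=O)C1=C(C)NC(C)=C(C(=O)OCc2ccccc2)C1c1cnc(SC)n1Nc1ccccc1` has not yet been measured. It keeps one benzyl ester of compound 3 and changes the other: methyl in place of phenyl on a saturated chain carbon bound to an oxygen next to a carbonyl group. Compound 4 thus sits between compound 3, carrying two benzyl esters, and compound 2, carrying two methyl esters. Among the compounds with values here, no single-change step between measured compounds is available to guide this.

On that basis the step from compound 3 to compound 4 in this assay is expected to be a small weakening, a 1.7-fold higher number from compound 3 to compound 4 (0.22 log units; within the scatter), possibly no larger than the scatter. Compound 4 is therefore estimated at 2.5 nM, within a range of 1 nM to 6 nM.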

Compound 4, half-maximal inhibitory concentration: 1.86 nM
The estimate for compound 4 lay 1.3-fold (0.13 log units) above the measured number, within the range that was stated.
By their numbers in this assay, from the lowest: compounds 3, 4, 2 and 1 (each within the scatter of the next, the first and the last beyond it).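

In this assay, exchanging benzyl for ethyl on one ester gives a 1.2-fold higher number from compound 3 to compound 4 (0.10 log units; within the scatter). Within the data shown here, this is the first comparison in the set that isolates a single place, and it shows that the phenyl on this ester chain, with its six-membered aromatic ring, can be replaced by a methyl without a difference this read-out can separate from the scatter. Nothing measured here bears on why the exchange leaves the number within the scatter.

Among these compounds, what the remaining ester contributes on its own stays open, as no single-change step isolates it. Also open, on these data alone, is how this read-out would respond at the same place to a carboxylic acid, an amine or a chain longer than ethyl.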